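Trimming a Methoxy Group from a Thiosemicarbazide Series

The source may report more compounds than this note shows. Statements on the series, on what has been measured and on what is new or still open speak of the compounds shown alone.

Compound 1 `COc1ccc(-c2cc(NC(=S)NNC(=O)c3ccc(C)cc3)cs2)cc1` gives 7000 nM in a functional assay on B16-F10 cells (Mus musculus) for inhibition, read by colorimetric assay and MTT assay, with a stated time of 72 h; a higher number here means a weaker inhibitor, a lower number a stronger inhibitor. Compound 2 `Cc1ccc(C(=O)NNC(=S)Nc2csc(-c3ccccc3)c2)cc1` differs from compound 1 by hydrogen in place of methoxy on an aromatic carbon, and in this assay compound 2 gives 24000 nM; that change made a 3.4-fold higher number from compound 1 to compound 2 (0.54 log units; beyond the scatter). Compound 3 `COc1cc(C(=O)NNC(=S)Nc2csc(-c3ccccc3)c2)cc(OC)c1OC` has a different core, and the difference between the two cores is not broken down here; in this assay compound 3 gives 32000 nM. Compound 4 `COc1cc(OC)cc(C(=O)NNC(=S)Nc2csc(-c3ccccc3)c2)c1` has not yet been measured and differs from compound 3 by hydrogen in place of methoxy on an aromatic carbon. This is the same kind of change as that from compound 1 to compound 2, though the place is not identical: here the carbon is ortho to two methoxy groups and para to a large group, whereas in compound 1 it is para to a large group only. Because the earlier step was a 3.4-fold higher number from compound 1 to compound 2 (0.54 log units; beyond the scatter), a step of similar size is expected, so compound 4 is expected to show a 1.9-fold higher number from compound 3 to compound 4 (0.27 log units; within the scatter) in this assay. The estimate for compound 4 in this assay is 60000 nM, expected to lie between 20000 nM and 180000 nM.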

Compound 4, half-maximal inhibitory concentration: 30000 nM
The estimate for compound 4 lay 2.0-fold (0.30 log units) above the measured number; measured number inside the range.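

In this assay, hydrogen in place of methoxy gave a 1.1-fold lower number from compound 3 to compound 4 (0.03 log units; within the scatter), so the two numbers cannot be told apart on this core. Among these compounds, the change therefore did not carry over at a fixed size from the core of compound 1 to the core of compound 3: the same change on two cores in this assay, a 3.4-fold higher number (0.54 log units; beyond the scatter) from compound 1 to compound 2 and a 1.1-fold lower number (0.03 log units; within the scatter) from compound 3 to compound 4, 3.7-fold (0.56 log units) apart, beyond the scatter of two such steps This rests on only two pairs, and it does not show what produced the gap, since the cores differ and the carbon that lost its methoxy is ortho to two methoxy groups in only one pair.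

The compounds shown leave open whether an amine or a hydroxyl group at the same carbon would separate from methoxy or hydrogen. They also leave open how the remaining methoxy groups of compound 4 contribute.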